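A few compounds are considered here, and "the series" means these few. Any claim that something is new, unique, unknown or untested is made for them only; others in the source may bear on it.

Working notes on the series. Compound 2, `CCCCCc1ccc(-c2c(C)[nH]c(=O)n2C2CCCCC2)cc1`, gives 10600 nM in a functional assay on brain (Rattus norvegicus, strain Wistar) for inhibition; a lower number here means a stronger inhibitor, a higher number a weaker inhibitor; of the three numbers in hand it is the second highest, with compound 1 nearest and compound 3 furthest. Compound 1, `CCCCCc1ccc(-c2c(C)[nH]c(=O)n2C)cc1`, gives 5900 nM, and the step of a 1.8-fold higher number from compound 1 to compound 2 (0.25 log units; within the scatter) stays within the scatter. Compound 3, `CCCCCCCCCCc1ccc(-c2c(C)[nH]c(=O)n2C2CCCCC2)cc1`, gives 27000 nM; the step of a 2.5-fold higher number from compound 2 to compound 3 (0.41 log units; beyond the scatter) is modest but beyond the scatter. Compound 4, `Cc1[nH]c(=O)n(C2CCCCC2)c1-c1ccc(Oc2ccccc2)cc1`, is not yet measured. It differs from compound 2 in one place: phenoxy in place of pentyl on an aromatic carbon. For the measured compounds named here, of the measured steps only the one from compound 2 to compound 3 bears on the para substituent, and there pentyl in place of hydrogen on a saturated chain carbon raised the number; phenoxy in place of pentyl is a replacement rather than a lengthening, so no measured step maps directly onto it. For compound 4 the expected step is a 1.1-fold higher number from compound 2 to compound 4 (0.05 log units; within the scatter), within the scatter. For compound 4 the estimated value is 12000 nM, with a range of 4000 nM to 36000 nM.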

Compound 4, half-maximal inhibitory concentration: 7900 nM
Estimate against measurement, compound 4: 1.5-fold (0.18 log units) above, and the stated range covers the measured number.
By their numbers in this assay, from the lowest: compounds 1, 4 and 2 (each within the scatter of the next); then compound 3.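

Phenoxy in place of pentyl on this aromatic carbon, para to a large group, gives a 1.3-fold lower number from compound 2 to compound 4 (0.13 log units; within the scatter) in this assay. The earlier step at this end of the molecule, a 2.5-fold higher number from compound 2 to compound 3 (0.41 log units; beyond the scatter), only lengthened a saturated chain, whereas this one shows that a group with a six-membered aromatic ring and a hydrogen-bond acceptor can replace the chain with no difference readable beyond the scatter. Nothing measured accounts for this result.

Still open, from the compounds shown here alone, is whether a group of another kind at this carbon, such as an amine, a carboxylic acid or a benzyloxy, would move the number beyond the scatter. Going by these compounds, it is also open whether substituents on the phenoxy ring itself, such as a chlorine or a methoxy, would change the number in either direction.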